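Amide aryl variation in the shared core series

This account rests on a few compounds, and the source may have more. Where it says the series, first, only, none or still open, it means among the compounds named here.

Compound 1 `CCN1CCN(c2cc(C)c3cc(NC(=O)c4cccc(Cl)c4)ccc3n2)CC1` gives 3820 nM in a functional assay on MCF7 cells (Homo sapiens) for antiproliferative activity, read by MTT assay, with a stated time of 72 h; on this read-out higher numbers stand for weaker inhibition and lower numbers for stronger inhibition.
Compound 2 `CCN1CCN(c2cc(C)c3cc(NC(=O)c4ccccc4OC)ccc3n2)CC1` gives 13200 nM in this assay.
Compound 3 `CCN1CCN(c2cc(C)c3cc(NC(=O)c4ccccc4Cl)ccc3n2)CC1` reaches only the assay limit in this assay, reported as > 50000 nM.

Compound 3 thus stands at the weak end of the three measured, and since its value is a limit rather than a number, the steps into it are limits too: an at least 13-fold higher number from compound 1 to compound 3 (1.11 log units; beyond the scatter) and an at least 3.7-fold higher number from compound 2 to compound 3 (0.57 log units; beyond the scatter). The 2-methoxyphenyl analogue sits between, with a 3.5-fold higher number from compound 1 to compound 2 (0.54 log units; beyond the scatter).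

Compound 4 `CCN1CCN(c2cc(C)c3cc(NC(=O)c4ccc[nH]4)ccc3n2)CC1` carries 1H-pyrrol-2-yl in place of 2-chlorophenyl on a carbonyl carbon. Among the measured compounds shown here, because an at least 13-fold higher number from compound 1 to compound 3 (1.11 log units; beyond the scatter) and an at least 3.7-fold higher number from compound 2 to compound 3 (0.57 log units; beyond the scatter) both weakened inhibition on arrival at the 2-chlorophenyl, leaving it is expected to lower the number again; no measured step shows how far a 1H-pyrrol-2-yl carries, so the expectation is a return toward the range of compounds 1 and 2 rather than beyond it. Compound 4 is therefore estimated at 15000 nM (range 3000 nM to 50000 nM), an expected step of an at least 3.3-fold lower number from compound 3 to compound 4 (0.52 log units; beyond the scatter) in this assay.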

Compound 4, half-maximal inhibitory concentration: 14700 nM
Compound 4: the middle estimate sits 1.0-fold (0.01 log units) above what was measured; low and high end bracket the measured number.
By their numbers in this assay, from the lowest: compound 1; then compounds 2 and 4 (each within the scatter of the next). At a limit, above all of these: compound 3.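

Among the compounds shown here, the 1H-pyrrol-2-yl, the first five-membered aromatic ring on this carbonyl carbon and the first group here with a hydrogen-bond donor, gives a measured number where the 2-chlorophenyl did not: an at least 3.4-fold lower number from compound 3 to compound 4 (0.53 log units; beyond the scatter). In this assay compound 3 remains a limit, not a number: the limit of > 50000 nM in this assay, at which 1 of the 4 values shown sits. The ring change matches the 2-methoxyphenyl, with a 1.1-fold higher number from compound 2 to compound 4 (0.05 log units; within the scatter), but falls short of the 3-chlorophenyl, with a 3.8-fold higher number from compound 1 to compound 4 (0.59 log units; beyond the scatter).

From the compounds shown here alone, whether the pyrrole hydrogen matters stays open. A 1-methylpyrrol-2-yl or furan-2-yl at this position would address that.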